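A few compounds are considered here, and "the series" means these few. Any claim that something is new, unique, unknown or untested is made for them only; others in the source may bear on it.

Working notes on the series. The shared core, seen in compound 1 `NC1=NC2(CCSCC2)N(OCCCOc2ccc(Cl)c(Cl)c2)C(N)=N1` and in compound 2 `NC1=NC2(CCOCC2)N(OCCCOc2ccccc2Br)C(N)=N1`, is tested in an assay on isolated protein for inhibition of Dihydrofolate reductase (Homo sapiens), read by spectrophotometry, using NADPH, with stated times of 5 s and 6 min, tested at 50 uM; a higher number here means a stronger effect of the compound at the concentration tested, a lower number a weaker effect. In this assay compound 1 gives 89.8%. Compound 2 gives 85% in this assay. The two numbers lie within the usual scatter of each other, so nothing separates compound 1 from compound 2 on these two readings.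

Compound 3 `NC1=NC2(CCSCC2)N(OCCCOc2cccc(Br)c2)C(N)=N1` is the next point. Against compound 1 it differs in one place: 3-bromophenyl in place of 3,4-dichlorophenyl on an oxygen on a saturated carbon. Among the compounds with values here, no step between measured compounds covers a change of this kind, so the size of the step is judged from the two numbers only. Both compound 1 and compound 2 stand high in this assay, and a move of no more than the scatter is expected from compound 1 to compound 3, in either direction or none at all. The expected step is a number 5.8 percentage points lower from compound 1 to compound 3 (within the scatter). For compound 3 the estimate in this assay is 84%, ranging from 68% to 94%.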

Compound 3, a percentage reported as inhibition, at one concentration (the size of the read-out at that concentration, not a potency): 86.5%
Compound 3: the middle estimate sits 2.5 percentage points below what was measured, within the range that was stated.
By their numbers in this assay, from the lowest: compounds 2, 3 and 1 (each within the scatter of the next).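

In this assay, within the data shown here, the single change at this position, 3-bromophenyl in place of 3,4-dichlorophenyl on an oxygen on a saturated carbon, gives a number 3.3 percentage points lower from compound 1 to compound 3 (within the scatter) and is the first one-place comparison. With the rest of compound 1 held fixed, the aromatic ring goes from two chlorine atoms to one bromine atom, and this read-out does not separate the two groups. No available measurement bears on why the two compounds read alike.

All the aromatic rings shown carry halogen, so it remains open how an unsubstituted phenyl, a methoxyphenyl or a phenyl bearing a carboxylic acid would read at this place. From the compounds shown here alone, a reading at one concentration also gives no potency, so any difference between the 3-bromophenyl and 3,4-dichlorophenyl compounds in potency remains open.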